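Removing trifluoromethyl from compound 3: an expected outcome

The source may report more compounds than this note shows. Statements on the series, on what has been measured and on what is new or still open speak of the compounds shown alone.

Measured so far in an ADME assay on MDBK cells (Bos taurus) for cytotoxicity, read by MTT assay, with a stated time of 96 h; a higher number here means that more compound is tolerated, a lower number that less compound is tolerated
- compound 1 (`CN(C)CCCN(/N=N/c1ccc([N+](=O)[O-])cc1)c1ccccc1`) gives 39000 nM
- compound 2 (`CN(C)CCCN(/N=N/c1cccc([N+](=O)[O-])c1)c1ccccc1`) gives 37000 nM
- compound 3 (`CN(C)CCCN(/N=N/c1ccccc1)c1cccc(C(F)(F)F)c1`) gives 38000 nM

Compound 3, at 38000 nM in this assay, lies within the scatter of both compound 1 and compound 2, so the three numbers cannot be put in any order. The three compounds carry different groups on the shared core, yet their values show no separation.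

The next compound is compound 4 (`CN(C)CCCN(/N=N/c1ccccc1)c1ccccc1`), which has hydrogen in place of trifluoromethyl on an aromatic carbon. Going by the values given here, no pair of measured compounds differs in one place only, so the data hold no direct measure of this change. The expectation therefore rests on the narrow spread of the three values, with compound 1 at 39000 nM and compound 2 at 37000 nM as the neighbours of compound 3. No step beyond the scatter is expected in this assay, although a direction cannot be firmly supported. The expected step is a 1.1-fold higher number from compound 3 to compound 4 (0.04 log units; within the scatter) and this remains an estimate. The estimate for compound 4 is 42000 nM (expected range 21000 nM to 90000 nM).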

Compound 4, half-maximal cytotoxic concentration: 95000 nM
Estimate against measurement, compound 4: 2.3-fold (0.35 log units) below; the measured number lies above the stated range.
By their numbers in this assay, from the lowest: compounds 2, 3 and 1 (each within the scatter of the next); then compound 4.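

In this assay, going by these compounds alone, hydrogen in place of trifluoromethyl on an aromatic carbon, meta to a large group, gives a 2.5-fold higher number from compound 3 to compound 4 (0.40 log units; beyond the scatter) and is the first change at this place that can be read directly. Hydrogen in place of nitro points the same way, with a 2.6-fold higher number from compound 2 to compound 4 (0.41 log units; beyond the scatter) and a 2.4-fold higher number from compound 1 to compound 4 (0.39 log units; beyond the scatter), so compound 4 stands apart from compounds 1, 2 and 3, and each of the three groups goes with less compound being tolerated than hydrogen does, although the three compounds that carry them cannot be told apart from one another. Nothing available here accounts for this shift or shows what lies behind it.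

The compounds shown leave open whether the step belongs to these particular groups or follows from having almost any group on the ring, since a methyl, a fluorine or a methoxy group at the same place would separate those two readings. They also leave open whether an amine or a carboxylic acid there would stay with compound 4 or fall in with compounds 1, 2 and 3.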